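Ring Changes at One Aromatic Carbon of a Shared Core

The compounds below may be only part of what the source reports. "The series", "measured", "known", "first", "only" and "open" are said of these compounds alone.

In an assay on isolated protein for displacement of a labelled ligand from melanin-concentrating hormone receptor 1 (Homo sapiens) (on this read-out lower numbers stand for stronger inhibition and higher numbers for weaker inhibition), three compounds have been measured:
compound 1 `CC1CCN(c2ccc3cc(NC(=O)CCc4ccc(C(F)(F)F)cc4)ccc3n2)C1` gives 2 nM;
compound 2 `O=C(CCc1ccc(C(F)(F)F)cc1)Nc1ccc2nc(N3CC4CC3CO4)ccc2c1` gives 13 nM;
compound 3 `O=C(CCc1ccc(C(F)(F)F)cc1)Nc1ccc2nc(N3CC4CCC3CC4)ccc2c1` gives 3 nM.

Compound 3 holds the second highest number of the three; a 1.5-fold higher number from compound 1 to compound 3 (0.18 log units; within the scatter), whereas a 4.3-fold lower number from compound 2 to compound 3 (0.64 log units; beyond the scatter). Compound 4 `O=C(CCc1ccc(C(F)(F)F)cc1)Nc1ccc2nc(N3CC4CCC3C4)ccc2c1` differs from compound 3 by a group of 7 heavy atoms (6 carbon, 1 nitrogen; one five-membered non-aromatic ring of carbon only, one five-membered non-aromatic ring with 1 hetero atom) in place of a group of 8 heavy atoms (7 carbon, 1 nitrogen; 2 six-membered non-aromatic rings with 1 hetero atom each), on an aromatic carbon. Among the compounds with values here, of the measured steps, the one from compound 1 to compound 3 is the closer analogy, since both keep rings of carbon only around one nitrogen, and it stayed within the scatter; the step from compound 2 to compound 3 shows that adding an oxygen did move the number. Compound 4 is therefore expected to show a 1.3-fold higher number from compound 3 to compound 4 (0.12 log units; within the scatter), nothing beyond the scatter. The estimate for compound 4 is 4 nM, in a range from 1.5 nM to 12 nM.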

Compound 4, half-maximal inhibitory concentration: 1 nM
The estimate for compound 4 lay 4.0-fold (0.60 log units) above the measured number; measured number outside the range, below it.
By their numbers in this assay, from the lowest: compounds 4, 1 and 3 (each within the scatter of the next, the first and the last beyond it); then compound 2.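

In this assay, within the data shown here, ring size in the group on this aromatic carbon turns out to count for more than the earlier compounds suggested, with a 3.0-fold lower number from compound 3 to compound 4 (0.48 log units; beyond the scatter). Between two groups of the same heavy-atom count, the one without oxygen gives a 13-fold lower number from compound 2 to compound 4 (1.11 log units; beyond the scatter), while a 2.0-fold lower number from compound 1 to compound 4 (0.30 log units; within the scatter) shows the group with two five-membered rings matching the single-ring group of the first compound. No measurement shown here explains these steps. On these data alone, whether a hydroxyl or a primary amine on the group of compound 4 would keep such numbers remains open.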